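Trimming the allyl side chain of compound 1

The source may hold more compounds than are shown below. What is called first, only, known or untested is meant among the compounds shown, and "the series" means these compounds.

In an ADME assay (Homo sapiens) for pharmacokinetics, read by HPLC (a lower number here means that the compound disappears faster, a higher number that the compound lasts longer), compound 1 (`C=CCC(OC(=O)[C@@H](Cc1ccc(OC(C)=O)c(OC(C)=O)c1)OC(C)=O)c1nc(C)c(C)nc1C`) gives 0.189 h. Within the data shown here, compound 2 (`C=CCC(CC=C)(OC(=O)[C@@H](Cc1ccc(OC(C)=O)c(OC(C)=O)c1)OC(C)=O)c1nc(C)c(C)nc1C`), the only other compound measured, gives 0.341 h, so compound 1 stands within the scatter of its sole comparator. Compound 3 (`CC(=O)Oc1ccc(C[C@@H](OC(C)=O)C(=O)OC(C)c2nc(C)c(C)nc2C)cc1OC(C)=O`) still awaits measurement. It differs from compound 1 in the side chain: hydrogen in place of vinyl on a saturated chain carbon, two bonds along the chain from an aromatic carbon and an oxygen next to a carbonyl group. This is hydrogen in place of vinyl on a saturated chain carbon, two bonds along the chain from an aromatic carbon and an oxygen next to a carbonyl group, or allyl to methyl. Among the measured compounds shown here, only one measured step touches this side chain, an allyl in place of hydrogen: a 1.8-fold higher number from compound 1 to compound 2 (0.26 log units; within the scatter). That single step offers no support for a change beyond the scatter in this assay. The expected outcome is a 1.1-fold lower number from compound 1 to compound 3 (0.02 log units; within the scatter). For compound 3 the estimated half-life is 0.18 h, with an expected range of 0.08 h to 0.38 h.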

Compound 3, half-life: 0.176 h
Beside the measured number, compound 3's estimate is 1.0-fold (0.01 log units) above it; measured number inside the range.
By their numbers in this assay, from the lowest: compounds 3, 1 and 2 (each within the scatter of the next).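

In this assay, cutting the allyl side chain down to methyl, hydrogen in place of vinyl, gives a 1.1-fold lower number from compound 1 to compound 3 (0.03 log units; within the scatter), so this side chain can be shortened as well as branched without leaving the scatter. Among these compounds, until now the only step at this carbon was the addition of a second allyl, a 1.8-fold higher number from compound 1 to compound 2 (0.26 log units; within the scatter), and the new step adds the first change to the chain itself. No measurement here explains why the number holds across these side chains.

As far as these compounds go, whether a longer chain, a cyclopropyl group or an amine at this position would shift the half-life beyond the scatter remains open. From the compounds shown here alone, all three compounds also carry the same acetyl esters on the shared core, so the effect of this side chain with free hydroxyl groups in their place remains open too.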